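Cyclopentyl on the Amide Nitrogen of Compound 1

The compounds below may be only part of what the source reports. "The series", "measured", "known", "first", "only" and "open" are said of these compounds alone.

Of the compounds shown here, three have been measured in an assay for inhibition of serine/threonine-protein kinase PLK2 (Homo sapiens), read by FRET and Z'-LYTE, with a stated time of 1 h; a lower number here means a stronger inhibitor, a higher number a weaker inhibitor. Compound 1, with the structure `CC[C@@H]1C(=O)N(C)c2cnc(-n3ccc4cc(C(N)=O)ccc43)nc2N1C1CCCC1`, gives 28.5 nM in this assay and has the lowest number of the three. Compound 3, with the structure `CCC1C(=O)N(C)c2cnc(Nc3ccc(S(N)(=O)=O)cc3)nc2N1c1ccn(C)n1`, gives 121 nM, and compound 2, with the structure `CCC1C(=O)N(C)c2cnc(-n3ccc4cc(F)ccc43)nc2N1c1ccn(C)n1`, gives 1500 nM. The gaps from compound 1 to compound 3 and from compound 1 to compound 2 both lie beyond the scatter, so compound 1 stands as the strongest of the three.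

Compound 4, with the structure `CC[C@@H]1C(=O)N(C)c2cnc(-n3ccc4cc(C(=O)NC5CCCC5)ccc43)nc2N1C1CCCC1`, has not been measured. It differs from compound 1 in one place: cyclopentyl in place of hydrogen on an amide-type nitrogen. Cut one bond further out, the change reads amino to cyclopentylamino, or carbamoyl to cyclopentylcarbamoyl.

Among the measured compounds shown here, no single-change step between measured compounds describes this kind of exchange, so there is nothing in the measured set to show how the number responds to it. The change is small in count and keeps the rest of the molecule untouched, so the expected step from compound 1 to compound 4 in this assay is a 1.4-fold higher number from compound 1 to compound 4 (0.15 log units; within the scatter), a shift that may well stay within the scatter. Compound 4 is therefore estimated at 40 nM, with a range from 12 nM to 130 nM.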

Compound 4, half-maximal inhibitory concentration: 7.06 nM
Estimate against measurement, compound 4: 5.7-fold (0.75 log units) above; measured number outside the range, below it.
By their numbers in this assay, from the lowest: compound 4; then compound 1; then compound 3; then compound 2.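

In this assay, cyclopentyl in place of hydrogen on the amide-type nitrogen gives a 4.0-fold lower number from compound 1 to compound 4 (0.61 log units; beyond the scatter), a modest step that lies beyond the scatter. Among the compounds shown here, this is the first single change in the set whose effect can be read directly, as compound 1, compound 2 and compound 3 differ from one another in more than one place and could not show how the number responds to any one exchange. It shows that, on this core, the amide hydrogen can give way to cyclopentyl with a lower number rather than a higher one, though nothing in the material shown explains the step.

The compounds shown leave open whether this step is particular to cyclopentyl or would also appear with a methyl, a cyclohexyl or a longer chain on the same nitrogen, or with an amine or a carboxylic acid carried on the cyclopentyl ring. They also leave open whether the step would hold if the cyclopentyl already present elsewhere on the core of compound 1 were exchanged for another group.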